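The source may hold more compounds than are shown below. What is called first, only, known or untested is meant among the compounds shown, and "the series" means these compounds.

Measured in a functional assay on HL-60 cells (Homo sapiens) for cytotoxicity, read by MTT assay, with a stated time of 48 h; a lower number here means a stronger inhibitor, a higher number a weaker inhibitor:
compound 1 `Nc1ccccc1Nc1n[n+]([O-])c2ccccc2[n+]1[O-]`: 8300 nM
compound 2 `[O-][n+]1nc(NC2CC2)[n+]([O-])c2ccccc21`: 3600 nM
compound 3 `O=[N+]([O-])c1ccc(CNc2n[n+]([O-])c3ccccc3[n+]2[O-])cc1`: 1400 nM

Compound 2 holds the middle place, the second highest of the three numbers, with both neighbouring values beyond the usual scatter. Next in the series is compound 4 `C=CCNc1n[n+]([O-])c2ccccc2[n+]1[O-]`, not yet measured. Its change from compound 2 is allyl in place of cyclopropyl on a nitrogen on an aromatic ring. Among the compounds with values here, no measured pair differs in one place only, so the data offer no direct guide to the size of this step. The estimated change, a 1.1-fold lower number from compound 2 to compound 4 (0.05 log units; within the scatter), is expected to stay within the scatter, with no clear direction. For compound 4 the expected value is 3200 nM, with an estimated range of 1300 nM to 7500 nM.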

Compound 4, half-maximal inhibitory concentration: 25800 nM
Compound 4: the middle estimate sits 8.1-fold (0.91 log units) below what was measured, and the stated range ends below it.
By their numbers in this assay, from the lowest: compound 3; then compound 2; then compound 1; then compound 4.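

In this assay, within the data shown here, allyl in place of cyclopropyl on a nitrogen on an aromatic ring gives a 7.2-fold higher number from compound 2 to compound 4 (0.86 log units; beyond the scatter) and provides the first single-place step. The two groups have the same count of carbon atoms, so atom count alone does not set the number at this position: a three-membered ring and an open chain with a double bond give clearly different results. No measurement at hand explains the size of this step. Open, as far as these compounds go, is where a saturated propyl chain or a cyclobutyl ring would fall relative to compound 2 and compound 4.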